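This account rests on a few compounds, and the source may have more. Where it says the series, first, only, none or still open, it means among the compounds named here.

In a functional assay on DU-145 cells (Homo sapiens) for inhibition, read by trypan blue exclusion, with a stated time of 72 h (on this read-out higher numbers stand for weaker inhibition and lower numbers for stronger inhibition), compound 1 (`Cn1c(=O)c(C(=O)Nc2ccc(F)cc2F)cc2cnc(Nc3ccc4[nH]ccc4c3)nc21`) gives 5000 nM, compound 2 (`COc1ccc(Nc2ncc3cc(S(=O)(=O)c4ccc(Cl)cc4)c(=O)n(C)c3n2)cc1`) gives 30000 nM, and compound 3 (`Cn1c(=O)c(S(=O)(=O)c2ccc(Cl)cc2)cc2cnc(Nc3ccc4[nH]ccc4c3)nc21`) gives 250 nM, the lowest of the three numbers. Compound 4 (`Cn1c(=O)c(S(=O)(=O)Nc2ccc(F)cc2F)cc2cnc(Nc3ccc4[nH]ccc4c3)nc21`) has not yet been measured. Its difference from compound 3 is (2,4-difluorophenyl)amino in place of 4-chlorophenyl on a sulfonyl sulfur. Among the measured compounds shown here, no measured step covers this exact change. The closest is a 20-fold lower number from compound 1 to compound 3 (1.30 log units; beyond the scatter), a large step, and compound 1 carries the same 2,4-difluorophenyl group that enters compound 4. The other large step, a 120-fold lower number from compound 2 to compound 3 (2.08 log units; beyond the scatter), concerns a group on a nitrogen that compound 4 shares with compound 3, so it bears little on this change. Compound 4 keeps the sulfonyl, so a move toward a higher number is expected, but a smaller one than the step involving compound 1. The expected change is a 4.0-fold higher number from compound 3 to compound 4 (0.60 log units; beyond the scatter). For compound 4 the estimated value is 1000 nM, with an expected range from 200 nM to 5000 nM.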

Compound 4, half-maximal inhibitory concentration: 5000 nM
Estimate against measurement, compound 4: 5.0-fold (0.70 log units) below, and the stated range covers the measured number.
By their numbers in this assay, from the lowest: compound 3; then compounds 1 and 4 (each within the scatter of the next); then compound 2.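

In this assay the exchange of 4-chlorophenyl for (2,4-difluorophenyl)amino on the sulfonyl sulfur gives a 20-fold higher number from compound 3 to compound 4 (1.30 log units; beyond the scatter) and so shows that the sulfonyl alone does not carry the low number of compound 3. The earlier step of a 20-fold lower number from compound 1 to compound 3 (1.30 log units; beyond the scatter) had changed the sulfonyl and its substituent together, whereas this result shows that the group on the sulfur matters by itself. With the sulfonyl kept, compound 4 gives 5000 nM in this assay and compound 1 gives 5000 nM in the same assay, the same printed number.

The compounds shown leave open whether the nitrogen or the change of ring substituents accounts for the step, since both enter together, and neither 2,4-difluorophenyl directly on the sulfur nor (4-chlorophenyl)amino appears among them. Nothing given here offers a reason for this step.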